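Swapping a Methoxy for a Trifluoromethyl Group

A few compounds are considered here, and "the series" means these few. Any claim that something is new, unique, unknown or untested is made for them only; others in the source may bear on it.

Compound 1 `COc1cccc(CN2CC=C(CCC(=O)NO)C2=O)c1`: 1770 nM
Compound 2 `COc1ccc(CN2CC=C(CCC(=O)NO)C2=O)cc1`: 1630 nM

In a functional assay on MDA-MB-231 cells (Homo sapiens) for antiproliferative activity (a lower number here means a stronger inhibitor of growth, a higher number a weaker inhibitor of growth), compound 1 gives 1770 nM, the higher of the two numbers. Compound 2 gives 1630 nM, and the gap between the two lies within the scatter, so neither stands apart.

Compound 3 `O=C(CCC1=CCN(Cc2cccc(C(F)(F)F)c2)C1=O)NO` differs from compound 1 by trifluoromethyl in place of methoxy on an aromatic carbon. For the measured compounds named here, no measured pair isolates this change, so its effect is open. A small step toward a lower number is expected, namely a 1.4-fold lower number from compound 1 to compound 3 (0.13 log units; within the scatter) in this assay, not clearly beyond the scatter. Compound 3 is estimated at 1300 nM, with a range from 500 nM to 3500 nM.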

Compound 3, concentration for 50% growth inhibition: 220 nM
Beside the measured number, compound 3's estimate is 5.9-fold (0.77 log units) above it; the measured number lies below the stated range.
By their numbers in this assay, from the lowest: compound 3; then compounds 2 and 1 (each within the scatter of the next).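

In this assay there is an 8.0-fold lower number from compound 1 to compound 3 (0.91 log units; beyond the scatter) when trifluoromethyl replaces methoxy on this aromatic carbon, meta to a large group. This shows that the group at this position can shift the number beyond the scatter, which compounds 1 and 2 alone did not show. Nothing given here accounts for the step.

On these data alone, whether a chlorine atom, a nitrile or an amine at this position would give a similar number remains open. So does the effect of trifluoromethyl at the position that carries methoxy in compound 2.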